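A few compounds are considered here, and "the series" means these few. Any claim that something is new, unique, unknown or untested is made for them only; others in the source may bear on it.

Measured so far:
- compound 1 `Cc1ccc(S(=O)(=O)c2cnc3ccc(Cl)cc3c2N2CCC(C)CC2)cc1C`: 84%
- compound 2 `CC1CCN(c2c(S(=O)(=O)c3cccc(C#N)c3)cnc3ccc(Cl)cc23)CC1`: 90%
- compound 3 `COc1cccc(S(=O)(=O)c2cnc3ccc(Cl)cc3c2N2CCC(C)CC2)c1`: 87%

All three share one core and differ only in the aryl group on the sulfonyl sulfur. In an assay on isolated protein for displacement of a labelled ligand from metabotropic glutamate receptor 5 (Homo sapiens), with a stated time of 60 min, tested at 1 uM (a lower number here means less inhibition, a higher number more inhibition at the concentration tested (going by the name of the read-out)), compound 1 gives 84%, compound 2 gives 90% and compound 3 gives 87%. Compound 3 stands second highest of the three numbers; its nearest neighbour is compound 1, at a number 3 percentage points higher from compound 1 to compound 3 (within the scatter), and its furthest is compound 2, at a number 3 percentage points lower from compound 2 to compound 3 (within the scatter), both within the scatter. The third step, a number 6 percentage points higher from compound 1 to compound 2 (within the scatter), is within the scatter as well. On this evidence the three aryl variants on the sulfonyl sulfur are indistinguishable in this assay.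

Compound 4 `Cc1cc(C)cc(S(=O)(=O)c2cnc3ccc(Cl)cc3c2N2CCC(C)CC2)c1` is not yet measured. Relative to compound 3 the change is 3,5-dimethylphenyl in place of 3-methoxyphenyl on a sulfonyl sulfur. Going by the values given here, the steps that bear on it are the aryl exchanges on the sulfonyl sulfur already seen, namely a number 3 percentage points higher from compound 1 to compound 3 (within the scatter) and a number 6 percentage points higher from compound 1 to compound 2 (within the scatter), neither of which left the scatter. A step beyond the scatter in this assay is therefore not expected in either direction. Compound 4 is expected to give 85%, with a range from 74% to 94%. The estimated step, a number 2 percentage points lower from compound 3 to compound 4 (within the scatter), is expected to stay inside the usual scatter.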

Compound 4, a percentage reported as inhibition, at one concentration (the size of the read-out at that concentration, not a potency): 49%
Compound 4: the middle estimate sits 36 percentage points above what was measured, outside the stated range (below it).
By their numbers in this assay, from the lowest: compound 4; then compounds 1, 3 and 2 (each within the scatter of the next).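

In this assay, going by these compounds alone, the aryl group on the sulfonyl sulfur proves sensitive to change, which the earlier compounds, all within the scatter of each other, did not reveal: the step is a number 38 percentage points lower from compound 3 to compound 4 (beyond the scatter) and, with the same entering group, a number 41 percentage points lower from compound 2 to compound 4 (beyond the scatter) and a number 35 percentage points lower from compound 1 to compound 4 (beyond the scatter) as well. The last of these is the sharpest comparison, since 3,4-dimethylphenyl and 3,5-dimethylphenyl differ only in how the two methyl groups are placed, so the presence of methyl groups or of an all-carbon aryl group does not by itself account for the lower number, and the loss of the hydrogen-bond acceptor in going from 3-methoxyphenyl to 3,5-dimethylphenyl cannot be taken as the explanation either. No measurement at hand gives a reason for this step.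

As far as these compounds go, whether the low number goes with the 3,5-pattern as such or with methyl groups in that pattern stays open, and 3,5-dimethoxyphenyl or 3,5-dichlorophenyl, read beside 3-methylphenyl, would separate the two. These are also readings at a single concentration on one shared core, so neither the potency of compound 4 nor the behaviour of this aryl change on another core can be stated.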